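Phenyl in place of tert-butyl in the hydroxy-amide arm

A few compounds are considered here, and "the series" means these few. Any claim that something is new, unique, unknown or untested is made for them only; others in the source may bear on it.

Compound 1 `CC(C)(C)[C@@H](O)C(=O)N1C[C@@H]2C[C@@H]2[C@H]1C(=O)NCc1cc(Cl)ccc1-n1cnnn1` and compound 2 `CC(C)(C)C[C@@H](O)C(=O)N1N=CC[C@H]1C(=O)NCc1cc(Cl)ccc1-n1cnnn1` carry the same amide-bearing arm on different cores; the difference between the two cores is not broken down here. Both were run in an ADME assay on liver for metabolic stability, with Liver microsome (Homo sapiens) as the target, read by LC-MS, using microsomes; on this read-out higher numbers stand for fast clearance and lower numbers for slow clearance. Compound 2 gives 22 mL.min-1.g-1. For compound 1 the result is a limit of the assay rather than a number, < 15 mL.min-1.g-1. Compound 3 `O=C(NCc1cc(Cl)ccc1-n1cnnn1)[C@@H]1CC=NN1C(=O)[C@H](O)Cc1ccccc1` differs from compound 2 in one place: phenyl in place of tert-butyl on a saturated chain carbon, two bonds along the chain from a carbonyl carbon and an oxygen on a saturated carbon. For compound 3 the assay again returns a limit and not a number, < 12 mL.min-1.g-1. The measured step is an at least 1.8-fold lower number from compound 2 to compound 3 (0.26 log units; that floor lies within the scatter), so compound 3 rests at the limit of < 12 mL.min-1.g-1 in this assay, at which 1 of the 3 values shown sits, while compound 1 rests at the limit of < 15 mL.min-1.g-1 in this assay, at which 1 of the 3 values shown sits.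

Compound 4 `O=C(NCc1cc(Cl)ccc1-n1cnnn1)[C@@H]1[C@H]2C[C@H]2CN1C(=O)[C@H](O)c1ccccc1` is the unmeasured partner of compound 1, and its difference from compound 1 reads: phenyl in place of tert-butyl on a saturated chain carbon bound to a carbonyl carbon and an oxygen on a saturated carbon. The two place descriptions are not the same word for word: in compound 4 the carbon that takes the phenyl is bound to a carbonyl carbon and an oxygen on a saturated carbon, whereas in compound 3 it is two bonds along the chain from a carbonyl carbon and an oxygen on a saturated carbon, so the two changes are of the same kind rather than the same.

Since compound 1 already sits at a limit, compound 4 is expected to remain slow in this assay, at an estimated 10 mL.min-1.g-1 with a range from 4 mL.min-1.g-1 to 22 mL.min-1.g-1. The expected step, a step that the limit leaves unreadable from compound 1 to compound 4, rests on an at least 1.8-fold lower number from compound 2 to compound 3 (0.26 log units; that floor lies within the scatter), which itself did not lift the lower compound above a limit.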

Compound 4, intrinsic clearance in microsomes: 61 mL.min-1.g-1
Compound 4: middle estimate off by 6.1-fold (0.79 log units), on the low side, and the stated range ends below it.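

In this assay, putting phenyl in place of tert-butyl on the core of compound 1 gives an at least 4.0-fold higher number from compound 1 to compound 4 (0.60 log units; beyond the scatter), so on this core the change brings a clear rise in clearance. The result therefore does not carry over in size or direction from the core of compound 2, and the two steps can be told apart: the same change on two cores in this assay, an at least 1.8-fold lower number (0.26 log units; that floor lies within the scatter) from compound 2 to compound 3 and an at least 4.0-fold higher number (0.60 log units; beyond the scatter) from compound 1 to compound 4, at least 7.4-fold (0.87 log units) apart, beyond the scatter of two such steps. This does not show that the core alone sets the outcome, as the phenyl sits on a carbon bound to a carbonyl carbon and an oxygen on a saturated carbon in compound 4, but two bonds along the chain from these in compound 3; each step also has one end that is a limit of the assay and not a number, and with only two pairs shown, no rule for the series follows.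

The compounds shown leave open how hydroxy(phenyl)methyl would read on the core of compound 2, and how the arm of compound 3 would read on the core of compound 1, which are the pairings needed to separate core from place. They also leave open how an amine or a carboxylic acid on the phenyl would read in this assay.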